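From Cyanophenyl to Hydroxyphenyl: an Expected Loss of Potency

The source may report more compounds than this note shows. Statements on the series, on what has been measured and on what is new or still open speak of the compounds shown alone.

Compound 1, `Cn1c(=O)c2c(cc(/C=C/c3cccc(N)n3)n2C)n(C)c1=O`, gives > 10000 nM in an assay on isolated protein for inhibition of Amine oxidase [flavin-containing] B (Homo sapiens), read by luminescence, with a stated time of 1 h (a higher number here means a weaker inhibitor, a lower number a stronger inhibitor), which is a limit of the assay rather than a number.
Compound 2, `Cn1c(=O)c2c(cc(/C=C/c3cccc(C#N)c3)n2C)n(C)c1=O`, gives > 10000 nM in this assay, again a limit rather than a number.
Compound 3, `Cn1c(=O)c2c(cc(/C=C/c3ccc(C#N)cc3)n2C)n(C)c1=O`, gives 543 nM in this assay.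

Within the data shown here, compound 3 therefore holds the only real number of the three; the other two sit at the limit of > 10000 nM in this assay, at which 2 of the 3 values shown sit. The steps leading to it are both large: an at least 18-fold lower number from compound 1 to compound 3 (1.26 log units; beyond the scatter) and an at least 18-fold lower number from compound 2 to compound 3 (1.26 log units; beyond the scatter), the latter showing that simply moving the nitrile from 3-cyanophenyl to 4-cyanophenyl turns a limit into a measurable value.

Compound 4, `Cn1c(=O)c2c(cc(/C=C/c3cccc(O)c3)n2C)n(C)c1=O`, differs from compound 3 in one place: 3-hydroxyphenyl in place of 4-cyanophenyl on a double-bonded chain carbon bound to a double-bonded chain carbon. Among the measured compounds shown here, no measured step exchanges a nitrile for a hydroxyl, so the nearest guide is the position change from compound 2 to compound 3, and the 3-hydroxyphenyl of compound 4 matches the 3-cyanophenyl of compound 2 in where its substituent sits. The same direction, reversed, is expected here.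

Compound 4 is thus expected to give 8000 nM, within a range of 1500 nM to 30000 nM. The expected step of a 15-fold higher number from compound 3 to compound 4 (1.17 log units; beyond the scatter) is a substantial rise, quite possibly ending at a limit again.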

Compound 4, half-maximal inhibitory concentration: > 1000 nM
Compound 4: only a limit was reported; the forecaster's own chance of this, stated with the estimate: 50%; the middle value does not contradict the limit.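

Compound 4 gives > 1000 nM in this assay, which is a limit of the assay and not a number. Exchanging 4-cyanophenyl for 3-hydroxyphenyl on this double-bonded chain carbon therefore gives an at least 1.8-fold higher number from compound 3 to compound 4 (0.26 log units; that floor lies within the scatter), so the result does not establish a loss beyond ordinary scatter, although a much larger loss remains possible. What is new is that a hydroxyl-bearing ring at this place also yields only a limit, and that this limit sits lower than those of compound 1 and compound 2, leaving compound 3 as the only compound here with a real number: the limit of > 1000 nM in this assay, at which 1 of the 4 values shown sits.

From the compounds shown here alone, the steps from compound 1 and compound 2 to compound 4 cannot be read, so it remains unknown how the 3-hydroxyphenyl ranks against the 3-cyanophenyl or the 6-aminopyridin-2-yl. Also open, going by these compounds, is whether the measurable value of compound 3 depends on the nitrile itself or on where it sits, which a 4-hydroxyphenyl, a 4-aminophenyl or a 4-carboxyphenyl in the same place could help to separate.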